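This account rests on a few compounds, and the source may have more. Where it says the series, first, only, none or still open, it means among the compounds named here.

Measured compounds:
- compound 1, `CN(C)CCNc1nc(NCc2ccco2)c2ccccc2n1`: "not determined" (no result reported) in a functional assay on HT-29 cells (Homo sapiens) for cytotoxicity, read by MTT assay, with a stated time of 2 days; on this read-out lower numbers stand for stronger inhibition and higher numbers for weaker inhibition
- compound 2, `Fc1ccc2nc(NCCCCN3CCN(c4cccc(Cl)c4Cl)CC3)nc(NCc3ccco3)c2c1`: 390 nM
- compound 3, `Clc1cccc(N2CCN(CCCNc3nc(NCc4ccco4)c4ccccc4n3)CC2)c1Cl`: 3370 nM

Compound 2 gives the lowest of the two numbers available in this assay. Within the data shown here, compound 3, the only other compound with a number, sits at a higher value, and that gap lies beyond the usual scatter; compound 3 differs from compound 2 in more than one place, so no single step can be read from the pair. Compound 1 contributes a structure but no number.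

The next compound, compound 4, `Cc1cccc(N2CCN(CCCCNc3nc(NCc4ccco4)c4cc(F)ccc4n3)CC2)c1C`, departs from compound 2 in one place: 2,3-dimethylphenyl in place of 2,3-dichlorophenyl on an amine nitrogen in a ring, a swap of two groups of equal heavy-atom count on an amine nitrogen in a ring. Among the measured compounds shown here, no measured pair isolates a change of this kind, so no step size is known. The expected step from compound 2 to compound 4 in this assay is a 1.7-fold higher number from compound 2 to compound 4 (0.22 log units; within the scatter), likely within or only slightly beyond the scatter. Compound 4 is therefore estimated at 650 nM, with a range from 200 nM to 2200 nM.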

Compound 4, half-maximal inhibitory concentration: 1830 nM
For compound 4 the middle estimate is 2.8-fold (0.45 log units) below the measured one; measured number inside the range.
By their numbers in this assay, from the lowest: compound 2; then compounds 4 and 3 (each within the scatter of the next).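

In this assay the series now has its first step read at a single place: on an amine nitrogen in a ring, 2,3-dimethylphenyl in place of 2,3-dichlorophenyl gives a 4.7-fold higher number from compound 2 to compound 4 (0.67 log units; beyond the scatter). The two groups have the same heavy-atom count, the same aromatic ring and the same hydrogen-bond donor and acceptor counts, yet the number still moves beyond the scatter, with compound 2 keeping the lower number. No measured property bears on this step.

On these data alone, whether the step depends on one or both ring substituents remains open, as does the standing of an unsubstituted phenyl, a 3-chlorophenyl or a 2-chlorophenyl at this place. The contributions of the chain and the ring fluorine also remain unseparated, since compound 2 and compound 3 differ in more than one place.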